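The compounds below may be only part of what the source reports. "The series", "measured", "known", "first", "only" and "open" are said of these compounds alone.

Of the compounds shown here, two have been measured in an assay on Sf9 cells for inhibition of protein deacetylase HDAC6 (Homo sapiens), read by fluorescence, with a stated time of 40 min; on this read-out higher numbers stand for weaker inhibition and lower numbers for stronger inhibition. Compound 1 `Cc1cccc(-c2nc(CNc3ccc(C(=O)NO)cc3)n(-c3ccccc3)n2)c1` gives 281 nM in this assay, and compound 2 `Cc1cccc(-n2nc(-c3ccccc3)nc2CNc2ccc(C(=O)NO)cc2)c1` gives 388 nM in this assay. Compound 1 has the lower of the two numbers, but its gap to compound 2 lies within the scatter of repeated measurements, so the two cannot be told apart on these data. Compound 3 `O=C(NO)c1ccc(NCc2nc(-c3ccc(F)cc3)nn2-c2ccccc2)cc1` has not yet been measured. It differs from compound 1 in one place: 4-fluorophenyl in place of 3-methylphenyl on an aromatic carbon. Among the compounds with values here, no measured pair in this set carries this change, so its effect can only be guessed from the two numbers in hand. The step of a 1.1-fold higher number from compound 1 to compound 3 (0.03 log units; within the scatter) is expected to be small, in either direction, and not beyond the scatter. Compound 3 is therefore expected to give about 300 nM in this assay, within a range from 120 nM to 750 nM.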

Compound 3, half-maximal inhibitory concentration: 115 nM
Compound 3: the middle estimate sits 2.6-fold (0.42 log units) above what was measured; the measured number lies below the stated range.
By their numbers in this assay, from the lowest: compound 3; then compounds 1 and 2 (each within the scatter of the next).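

In this assay, the group on the aromatic carbon of the five-membered ring proves able to shift the number: 4-fluorophenyl in place of 3-methylphenyl gives a 2.4-fold lower number from compound 1 to compound 3 (0.39 log units; beyond the scatter), a modest step. The two groups match in heavy-atom count, in their hydrogen-bond donor and acceptor counts and in net charge, so those counts do not separate them. Nothing at hand explains the step.

This single pair cannot separate the loss of the methyl group from the gain of the fluorine, nor either of these from the change in where the substituent sits on the phenyl ring. It also leaves open how an unsubstituted phenyl, 4-methylphenyl, 3-fluorophenyl or 4-chlorophenyl group would read at this position.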